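The source may report more compounds than this note shows. Statements on the series, on what has been measured and on what is new or still open speak of the compounds shown alone.

Measured compounds in a functional assay on HeLa cells (Homo sapiens) for antiproliferative activity, read by sulforhodamine B assay, with a stated time of 48 h; a lower number here means a stronger inhibitor of growth, a higher number a weaker inhibitor of growth:
- compound 1, `O=C(NCc1cn(Cc2ccc(Cl)cc2)nn1)c1cn(-c2ccccc2)nc1-c1ccccc1`: 600 nM
- compound 2, `O=C(NCc1cn(Cc2ccc(C(F)(F)F)cc2)nn1)c1cn(-c2ccccc2)nc1-c1ccccc1`: 1600 nM
- compound 3, `COc1cc(Cn2cc(CNC(=O)c3cn(-c4ccccc4)nc3-c3ccccc3)nn2)cc(OC)c1OC`: reported only as a limit of this assay, > 100000 nM

Compound 1 holds the lowest of the two numbers in this assay; the step of a 2.7-fold higher number from compound 1 to compound 2 (0.43 log units; beyond the scatter) sets it apart from compound 2 by a modest margin. Compound 3 reaches the limit described by the limit of > 100000 nM in this assay, at which 1 of the 3 values shown sits. The steps of an at least 160-fold higher number from compound 1 to compound 3 (2.22 log units; beyond the scatter) and an at least 62-fold higher number from compound 2 to compound 3 (1.79 log units; beyond the scatter) are therefore large, and both arise from swapping the benzyl substituent on the triazole.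

Compound 4, `O=C(NCc1cn(Cc2ccc(Cl)cc2)nn1)c1cn(-c2ccccc2)nc1-c1ccc(F)cc1`, differs from compound 1 by fluoro in place of hydrogen on an aromatic carbon; the change sits on the phenyl attached to a core carbon, on the far side of the molecule from where the three measured compounds differ. None of the measured steps alters this phenyl, so none bears directly on the change; the only steps shown concern the benzyl group, and they say nothing about substitution of the core phenyl.

For the measured compounds named here, with no guiding step, the expectation for compound 4 is a step of no change at the digits printed from compound 1 to compound 4 (within the scatter), not beyond the scatter of this assay. Compound 4 is therefore estimated at 600 nM, with a range from 250 nM to 1500 nM.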

Compound 4, concentration for 50% growth inhibition: 210 nM
Beside the measured number, compound 4's estimate is 2.9-fold (0.46 log units) above it; the whole stated range lies above it.
By their numbers in this assay, from the lowest: compound 4; then compound 1; then compound 2. At a limit, above all of these: compound 3.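

Working notes on the series: in this assay, the phenyl on the core carbon is a position that responds to substitution, as fluoro in place of hydrogen on this aromatic carbon, para to a large group, gives a 2.9-fold lower number from compound 1 to compound 4 (0.46 log units; beyond the scatter). For the compounds shown here, the earlier steps all lay in the benzyl group on the triazole and all raised the number from compound 1, so this single added fluorine is the first change from compound 1 to lower the number, and it does so at the other end of the molecule. The data shown give no measured property that accounts for this step.

Still open, as far as these compounds go, is whether the step belongs to fluoro itself or to any group at this position, since chloro, methoxy, an amine or a carboxylic acid in the same place would separate those two readings. Also open, from the compounds shown here alone, is whether the change carries over to the 4-(trifluoromethyl)benzyl compound 2, and whether the other phenyl of the shared core responds to fluoro in the same way.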